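From 4-hydroxyphenyl to 3,4-dihydroxyphenyl in compound 3

The compounds below may be only part of what the source reports. "The series", "measured", "known", "first", "only" and "open" are said of these compounds alone.

Going by the values given here, in a physicochemical assay, read by spectrophotometry, with a stated time of 30 min (a lower number here means a stronger inhibitor, a higher number a weaker inhibitor), compound 1 `COc1ccc(/C=N/NC(=O)CCCc2nc3ccccc3c(=O)[nH]2)cc1` gives 247000000 nM and compound 2 `O=C(CCCc1nc2ccccc2c(=O)[nH]1)N/N=C/c1ccc(O)cc1` gives 214000000 nM, so compound 2 stands within the scatter of the only other measured compound. Compound 3 `O=C(CCCc1nc2ccccc2c(=O)[nH]1)N/N=C/c1ccc(O)c(O)c1` differs from compound 2 in one place: hydroxy in place of hydrogen on an aromatic carbon. A hydroxy takes the place of a hydrogen on an aromatic carbon, ortho to a hydroxy group, which turns 4-hydroxyphenyl into 3,4-dihydroxyphenyl. Among the compounds with values here, only one measured step bears on this change: a 1.2-fold lower number from compound 1 to compound 2 (0.06 log units; within the scatter). That step swaps methyl for hydrogen on an oxygen and adds no new hydroxy on the ring, so it sets no size for the change here. A lower number in this assay is still expected, though with much uncertainty. The expected change is a 3.6-fold lower number from compound 2 to compound 3 (0.55 log units; beyond the scatter). For compound 3 the estimate is 60000000 nM, with an expected range of 10000000 nM to 230000000 nM.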

Compound 3, half-maximal inhibitory concentration: 95000000 nM
Compound 3: middle estimate off by 1.6-fold (0.20 log units), on the low side; the measured number falls inside the stated range.
By their numbers in this assay, from the lowest: compound 3; then compounds 2 and 1 (each within the scatter of the next).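

In this assay, going by these compounds alone, a new hydroxy on the ring gives a 2.3-fold lower number from compound 2 to compound 3 (0.35 log units; beyond the scatter) and so produces the first step beyond the scatter in this small set. The earlier step, hydrogen in place of methyl on the oxygen, stayed within the scatter, so the ring carbon ortho to a hydroxy group is a place where a change can register, though only modestly. The full change from 4-methoxyphenyl to 3,4-dihydroxyphenyl gives a 2.6-fold lower number from compound 1 to compound 3 (0.41 log units; beyond the scatter) and is close in size to the single added hydroxy.

On these data alone, whether an amine or a carboxylic acid on this same ring carbon would lower the number as the hydroxy does remains open, and so does the effect of a longer chain between the ring and the shared core. No measurement shown here speaks to why the number falls.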